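A trifluoromethoxy swap on a compound at the limit

A few compounds are considered here, and "the series" means these few. Any claim that something is new, unique, unknown or untested is made for them only; others in the source may bear on it.

Measured in a functional assay on SEM cells (Homo sapiens) for cytotoxicity, with a stated time of 72 h; on this read-out lower numbers stand for an effect already at smaller amounts and higher numbers for an effect only at larger amounts of compound:
- Compound 1 `C=C[C@@](C)(/C=C/c1ccc(Nc2ccccc2)cc1)CCC=C(C)C`: > 36600 nM (a limit)
- Compound 2 `C=C[C@@](C)(/C=C/c1ccc(Nc2cccc(OC(F)(F)F)c2)cc1)CCC=C(C)C`: > 36600 nM (a limit)

As far as these compounds go, compound 1 gives no actual number in this assay, only a limit, so its true position is unknown. Compound 3 `C=C[C@@](C)(/C=C/c1ccc(Nc2ccc(OC(F)(F)F)cc2)cc1)CCC=C(C)C` differs from compound 1 in one place: trifluoromethoxy in place of hydrogen on an aromatic carbon. Among the measured compounds shown here, the one measured step that bears on this is a step that the two limits leave unreadable from compound 1 to compound 2, which makes the same kind of exchange on an aromatic carbon. For the measured compounds named here, the only evidence from that pair is the limit of > 36600 nM in this assay, at which 2 of the 2 values shown sit. No size can be read from it, so no clear step is expected in this assay in either direction, and a further limit is the likeliest report. The estimated change is a step that the limit leaves unreadable from compound 1 to compound 3. For compound 3 the expected value is 40000 nM, with an estimated range from 15000 nM to 80000 nM.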

Compound 3, half-maximal effective concentration: > 36600 nM
Compound 3 was reported as a limit (the forecaster's own chance of this, stated with the estimate: 85%); the middle value is on the limit's open side.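

Among the compounds shown here, compound 1, compound 2 and compound 3 all end at a limit rather than a number, so no step between them can be read. What they share is this: the limit of > 36600 nM in this assay, at which 3 of the 3 values shown sit.

As far as these compounds go, whether trifluoromethoxy on either position shifts the effect in this assay at all stays open, as does the true value of each compound.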